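The source may hold more compounds than are shown below. What is called first, only, known or untested is meant among the compounds shown, and "the series" means these compounds.

Compound 2 `N#Cc1ccc(Nc2nc(Oc3ccnc4ccccc34)nc(N3CCN(c4ccccc4Cl)CC3)n2)cc1C(F)(F)F` belongs to a small set of three compounds tested in a functional assay on DU-145 cells (Homo sapiens) for cytotoxicity, read by sulforhodamine B assay, with a stated time of 48 h; on this read-out lower numbers stand for stronger inhibition of growth and higher numbers for weaker inhibition of growth. In this assay compound 2 gives 92600 nM, and compound 1 `N#Cc1ccc(Nc2nc(Oc3ccnc4ccccc34)nc(N3CCCCC3)n2)cc1C(F)(F)F` gives 94900 nM; the two numbers sit within the usual scatter of one another, so neither stands apart. For compound 3 `COc1ccc(CN2CCN(c3nc(Nc4ccc(C#N)c(C(F)(F)F)c4)nc(Oc4ccnc5ccccc45)n3)CC2)c(OC)c1OC` this assay yields only a limit, > 100000 nM. Compound 4 `N#Cc1ccc(Nc2nc(Oc3ccnc4ccccc34)nc(N3CCN(c4ccccc4)CC3)n2)cc1C(F)(F)F` has not yet been measured; it differs from compound 2 by hydrogen in place of chloro on an aromatic carbon. No step between measured compounds is known, so the weight of this change cannot be read from any pair shown. The step from compound 2 to compound 4 is expected to be none beyond the scatter a 1.0-fold higher number from compound 2 to compound 4 (0.01 log units; within the scatter). Compound 4 is estimated at 95000 nM, within a range from 45000 nM to 190000 nM.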

Compound 4, concentration for 50% growth inhibition: > 100000 nM
Compound 4 was reported as a limit (the forecaster's own chance of this, stated with the estimate: 40%); middle value at least 1.0-fold (0.02 log units) from the limit.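

In this assay, the change from 2-chlorophenyl to phenyl gives an at least 1.0-fold higher number from compound 2 to compound 4 (0.03 log units; that floor lies within the scatter), and 4-phenylpiperazin-1-yl in place of piperidin-1-yl gives an at least 1.0-fold higher number from compound 1 to compound 4 (0.02 log units; that floor lies within the scatter). Neither floor shows a change beyond the scatter, so the chloro is not shown to matter at this place, and the true size of both steps stays unknown. Compound 4 joins compound 3 at the top of the measurable range: the limit of > 100000 nM in this assay, at which 2 of the 4 values shown sit.

Going by these compounds, it remains open whether a fluoro, a methoxy or an amine on this ring would give a readable value well clear of that limit.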